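A few compounds are considered here, and "the series" means these few. Any claim that something is new, unique, unknown or untested is made for them only; others in the source may bear on it.

Measured compounds:
compound 1 `Cc1ccc(C(=O)NC2=C(C#N)C(c3ccc(Cl)cc3Cl)C3=C(CCCC3=O)N2c2ccc(S(N)(=O)=O)cc2)cc1` — 40%
compound 2 `COc1cc(C(=O)NC2=C(C#N)C(c3ccc(Cl)cc3Cl)C3=C(CCCC3=O)N2c2ccc(S(N)(=O)=O)cc2)cc(OC)c1OC` — 95%
compound 3 `NC(=O)C1=C(N)N(c2ccc(S(N)(=O)=O)cc2)C2=C(C(=O)CCC2)C1c1ccc(Cl)cc1Cl` — 45%

In a functional assay on Ehrlich cells (Mus musculus) for cytotoxicity, read by trypan blue exclusion, with a stated time of 2 h, tested at 100 ug/mL (on this read-out lower numbers stand for a weaker effect and higher numbers for a stronger effect at the one concentration tested), compound 1 gives 40%, the lowest of the three numbers. Compound 3 sits nearest to it, and the two lie within the scatter of each other. Going by the values given here, compound 2 is furthest away: the one measured step, a number 55 percentage points higher from compound 1 to compound 2 (beyond the scatter), came from putting 3,4,5-trimethoxyphenyl in place of 4-methylphenyl on a carbonyl carbon.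

Compound 4 `CN(C)c1ccc(/C=N/C2=C(C#N)C(c3ccc(Cl)cc3Cl)C3=C(CCCC3=O)N2c2ccc(S(N)(=O)=O)cc2)cc1` has not yet been measured. Relative to compound 1 it carries a group of 11 heavy atoms (9 carbon, 2 nitrogen; one six-membered aromatic ring of carbon only) in place of a group of 10 heavy atoms (8 carbon, 1 nitrogen, 1 oxygen; one six-membered aromatic ring of carbon only), on a double-bonded ring carbon. The measured step from compound 1 to compound 2 changed only the aryl group on the carbonyl carbon and kept the amide; the change to compound 4 removes the carbonyl and its amide hydrogen altogether, so that step does not bear directly on it. Among the compounds with values here, compound 3 differs from compound 1 in more than one place, so its value offers no step either. With nothing that speaks to this change, the expected step is a number 10 percentage points higher from compound 1 to compound 4 (within the scatter), and compound 4 is estimated at 50%, with a range from 25% to 85%.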

Compound 4, a percentage reported as activity, at one concentration (the size of the read-out at that concentration, not a potency): 40%
Compound 4: middle estimate off by 10 percentage points, on the high side; measured number inside the range.
By their numbers in this assay, from the lowest: compounds 1, 4 and 3 (each within the scatter of the next); then compound 2.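

In this assay, the read-out gives no change at the digits printed from compound 1 to compound 4 (within the scatter), so at this double-bonded ring carbon the carbonyl and the amide hydrogen can both be lost without any change that can be told from scatter. The entering group has no hydrogen-bond donor, where the leaving ((4-methylphenyl)carbonyl)amino group has one, so a donor at this place is not needed to keep the effect of compound 1 at this one concentration. No measurement at hand explains this outcome.

On these data alone, since the link and the substituent on the aromatic ring change together in compound 4, their separate contributions stay unknown. As far as these compounds go, it also remains open whether a 3,4,5-trimethoxyphenyl group on the carbonyl-free link would reach the value of compound 2, or how a pyridine ring would fare in place of the benzene ring.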